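This account rests on a few compounds, and the source may have more. Where it says the series, first, only, none or still open, it means among the compounds named here.

The compounds here are judged in an ADME assay on MT4 cells (Homo sapiens) for cytotoxicity, read by MTT assay; on this read-out lower numbers stand for higher toxicity in this test and higher numbers for lower toxicity in this test. Compound 1 `O=C(CSc1nc(Cc2c(Cl)cccc2Cl)cc(=O)[nH]1)c1ccccc1` gives > 12000 nM, which is a limit of the assay and not a number, so it has no exact place on the scale. Compound 2 `O=C(CSc1nc(Cc2c(Cl)cccc2Cl)cc(=O)[nH]1)c1ccc(F)cc1` gives > 59000 nM, which is also a limit. Among the compounds with values here, the only measured step is a step that the two limits leave unreadable from compound 1 to compound 2, with fluoro in place of hydrogen on an aromatic carbon, and it offers no size to carry over. Compound 3 `CCc1c(Cc2c(Cl)cccc2Cl)nc(SCC(=O)c2ccccc2)[nH]c1=O` keeps the core of compound 1 and takes ethyl in place of hydrogen on an aromatic carbon. Within the data shown here, this is a different change, and no measured step covers it. Among the measured compounds shown here, with a step that the two limits leave unreadable from compound 1 to compound 2 as the only guide, no move toward a clearly lower number, meaning higher toxicity in this test, is expected, and this assay may well report only a limit again. The expected step that the limit leaves unreadable from compound 1 to compound 3 is therefore a rough estimate, with a slight lean toward a higher number. For compound 3 the estimated value is 30000 nM, with an expected range of 10000 nM to 100000 nM.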

Compound 3, half-maximal cytotoxic concentration: > 52000 nM
Compound 3 ended at the assay's limit; the forecaster's own chance of this, stated with the estimate: 65%; middle value at least 1.7-fold (0.23 log units) from the limit.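

In this assay compound 3 gives > 52000 nM, which is a limit of the assay and not a number. Compound 1 also stands only at a limit, so no step can be read from compound 1 to compound 3. The compounds shown leave open where the true values of compound 1, compound 2 and compound 3 lie, and whether ethyl in place of hydrogen changes the value at all.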